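The source may hold more compounds than are shown below. What is called first, only, known or untested is meant among the compounds shown, and "the series" means these compounds.

Three compounds have been measured in a functional assay on HeLa cells (Homo sapiens) for antiproliferative activity, with a stated time of 48 h; on this read-out higher numbers stand for weaker inhibition and lower numbers for stronger inhibition:

Compound 1, `C=C(Br)C(=O)Nc1ccc(/C=C/C(=O)c2ccc(Br)cc2)cc1`, gives 1000 nM.
Compound 2, `C=C(Br)C(=O)Nc1ccc(C(=O)/C=C/c2ccccc2)cc1`, gives 960 nM.
Compound 3, `Nc1ccc(/C=C/C(=O)c2ccc(Br)cc2)cc1`, gives 49000 nM.

Compound 1 and compound 3 share one core and differ only at the amide: hydrogen in place of (1-bromoethenyl)carbonyl on a nitrogen on an aromatic ring. This change produced a 49-fold higher number from compound 1 to compound 3 (1.69 log units; beyond the scatter). Compound 2 is built on a second core; how the two cores differ is not broken down here, and in this assay the numbers for compound 1 and compound 2 lie within the usual scatter of each other.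

Compound 4, `Nc1ccc(C(=O)/C=C/c2ccccc2)cc1`, has not yet been measured. It relates to compound 2 exactly as compound 3 relates to compound 1: hydrogen in place of (1-bromoethenyl)carbonyl on a nitrogen on an aromatic ring. The place is the same in both pairs, so this is the same change made on the second core. For compound 4 the expected step is a 49-fold higher number from compound 2 to compound 4 (1.69 log units; beyond the scatter), since the identical change gave a 49-fold higher number from compound 1 to compound 3 (1.69 log units; beyond the scatter). On that basis compound 4 is estimated to give 47000 nM in this assay, expected to fall between 15000 nM and 150000 nM.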

Compound 4, half-maximal inhibitory concentration: 7700 nM
Compound 4: middle estimate off by 6.1-fold (0.79 log units), on the high side, and the stated range ends above it.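

In this assay, putting hydrogen in place of (1-bromoethenyl)carbonyl on the nitrogen on the aromatic ring gave an 8.0-fold higher number from compound 2 to compound 4 (0.90 log units; beyond the scatter), so the number rose on the second core as it had on the first. The size of the rise did not carry over, since the two steps stand apart by more than their scatter: the same change on two cores in this assay, a 49-fold higher number (1.69 log units; beyond the scatter) from compound 1 to compound 3 and an 8.0-fold higher number (0.90 log units; beyond the scatter) from compound 2 to compound 4, 6.1-fold (0.79 log units) apart, beyond the scatter of two such steps. For these two cores, then, the direction of the change was carried from one to the other but its size was not, and two pairs do not show why the steps differ or what the change would do on any further core.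

In both pairs the whole (1-bromoethenyl)carbonyl group leaves at once, so the compounds shown leave open how much of the step would remain with a smaller group on that nitrogen, such as an acetyl group or a propenoyl group without the bromine. They also leave open which feature of the two cores sets the size of the step.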